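Compound 3 to compound 4: how much is left?

The source may hold more compounds than are shown below. What is called first, only, known or untested is meant among the compounds shown, and "the series" means these compounds.

Measured in a physicochemical assay, read by HPLC, in phosphate buffer, with a stated time of 2 h, at pH 7.4; a lower number here means that less of the compound is left, a higher number that more of the compound is left
- compound 1 `CC(OC(=O)N1CCN(C(=O)c2nc(Nc3cc(C4CC4)[nH]n3)c3cc(Cl)ccc3n2)C[C@H]1C)OC(=O)C(C)(C)C` gives 90.5%
- compound 2 `COC(=O)N1CCN(C(=O)c2nc(Nc3cc(C4CC4)[nH]n3)c3cc(Cl)ccc3n2)C[C@H]1C` gives 100%
- compound 3 `CC(OC(=O)C(C)C)OC(=O)N1CCN(C(=O)c2nc(Nc3cc(C4CC4)[nH]n3)c3cc(Cl)ccc3n2)C[C@H]1C` gives 96.6%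

Compound 3, at 96.6%, lies within the scatter of both other compounds. Compound 4 `CC(C)OC(=O)N1CCN(C(=O)c2nc(Nc3cc(C4CC4)[nH]n3)c3cc(Cl)ccc3n2)C[C@H]1C` differs from it by methyl in place of (isopropylcarbonyl)oxy on a saturated chain carbon bound to an oxygen next to a carbonyl group and a saturated chain carbon, with methyl in place of (isopropylcarbonyl)oxy on a saturated chain carbon bound to an oxygen next to a carbonyl group and a saturated chain carbon. The closest measured change is a number 3.4 percentage points lower from compound 2 to compound 3 (within the scatter), where 1-((isopropylcarbonyl)oxy)ethyl takes the place of methyl. The other two measured steps, a number 6.1 percentage points higher from compound 1 to compound 3 (within the scatter) and a number 9.5 percentage points higher from compound 1 to compound 2 (within the scatter), also stay within the scatter, so no step beyond the scatter is expected in this assay. The expected step is a number 1.4 percentage points higher from compound 3 to compound 4 (within the scatter). Compound 4 is estimated at 98%, with an expected range from 91% to 102%.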

Compound 4, percent of the compound remaining: 99%
Compound 4: middle estimate off by 1 percentage points, on the low side, and the stated range covers the measured number.
By their numbers in this assay, from the lowest: compounds 1, 3, 4 and 2 (each within the scatter of the next).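

In this assay methyl in place of (isopropylcarbonyl)oxy gives a number 2.4 percentage points higher from compound 3 to compound 4 (within the scatter) and methyl in place of ((tert-butyl)carbonyl)oxy gives a number 8.5 percentage points higher from compound 1 to compound 4 (within the scatter) on the same saturated chain carbon. Isopropyl in place of methyl on an oxygen next to a carbonyl group gives a number 1 percentage points lower from compound 2 to compound 4 (within the scatter) in turn, so removing the acyloxy part leaves the amount remaining within the scatter of all three earlier compounds. Nothing available explains this result. Still open, from the compounds shown here alone, is whether an amine, a carboxylic acid or a longer chain on that oxygen would also stay within the scatter.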